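Amine methylation on the shared core: estimating compound 4

A few compounds are considered here, and "the series" means these few. Any claim that something is new, unique, unknown or untested is made for them only; others in the source may bear on it.

Measured so far:
Compound 1, `CNCc1cc2cnccc2s1`: in an assay on isolated protein for inhibition of cytochrome P450 2A6 (Homo sapiens), read by fluorescence, with a stated time of 10 min (a lower number here means a stronger inhibitor, a higher number a weaker inhibitor), compound 1 gives 1500 nM.
Compound 2, `O=Cc1c[nH]c2cccc(Br)c12`: in this assay compound 2 gives 12000 nM.
Compound 3, `CN(C)Cc1cc2cnccc2s1`: in this assay compound 3 gives 1400 nM.

Compound 3 sits at the low end of the three numbers in this assay. Its gap to compound 1 is within the scatter, as the step of a 1.1-fold lower number from compound 1 to compound 3 (0.03 log units; within the scatter) shows, so no order between these two can be claimed. Among the compounds with values here, compound 2, built on a different core, lies beyond the scatter above compound 3, and no single-point step connects it to the rest.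

The next compound, compound 4, `NCc1cc2cnccc2s1`, differs from compound 3 in one place: amino in place of dimethylamino on a saturated chain carbon bound to an aromatic carbon. Within the data shown here, the only measured step that bears on this is the addition of a methyl on the same amine nitrogen, a 1.1-fold lower number from compound 1 to compound 3 (0.03 log units; within the scatter), which was within the scatter. Removing the remaining methyl is taken to behave alike, with a slight lean toward a higher number since the step is larger than any shown. Compound 4 is therefore expected to give 1800 nM in this assay, within a range of 800 nM to 4000 nM. This estimate implies an expected step of a 1.3-fold higher number from compound 3 to compound 4 (0.11 log units; within the scatter), not beyond the scatter.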

Compound 4, half-maximal inhibitory concentration: 1000 nM
For compound 4 the middle estimate is 1.8-fold (0.26 log units) above the measured one; low and high end bracket the measured number.
By their numbers in this assay, from the lowest: compounds 4, 3 and 1 (each within the scatter of the next); then compound 2.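

In this assay the series now gives a 1.4-fold lower number from compound 3 to compound 4 (0.15 log units; within the scatter) and also a 1.5-fold lower number from compound 1 to compound 4 (0.18 log units; within the scatter), so both new steps stay within the scatter. The amine on the saturated chain carbon bound to an aromatic carbon therefore tolerates the full change from dimethylamino to amino without a readable difference, whereas the earlier pair covered only a single methyl on the amine nitrogen. Nothing available here accounts for this flat response.

Still open, going by these compounds, is whether it holds for larger groups on this nitrogen, such as ethyl, acetyl or a pyrrolidine ring, or for a longer chain carrying the amine. Compound 2 differs from the others in more than one place and so gives no reading on this position.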